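The source may hold more compounds than are shown below. What is called first, only, known or untested is meant among the compounds shown, and "the series" means these compounds.

Compound 1, with structure `CC(C)C(C)Nc1cc(NC(=O)c2cccs2)cc(C(F)(F)F)c1`, was tested in an assay on HEK293-TREx cells for antagonist activity at transient receptor potential cation channel subfamily A member 1 (Homo sapiens), read by calcium flux (a lower number here means a stronger inhibitor, a higher number a weaker inhibitor), and gave 1300 nM. Compound 2, with structure `CCCNc1cc(NC(=O)c2ccccn2)cc(C(F)(F)F)c1`, carries a propyl chain on the amine and a pyridin-2-yl group on the carbonyl carbon. In this assay compound 2 gave only > 32000 nM, which is a limit of the assay and not a number. Among the two values shown, (the limit of > 32000 nM in this assay, at which 1 of the 2 values shown sits), so compound 2 is known only to be a weak inhibitor. Compound 3, with structure `CCCNc1cc(NC(=O)c2ccc(F)c(F)c2)cc(C(F)(F)F)c1`, differs from compound 2 in one place: 3,4-difluorophenyl in place of pyridin-2-yl on a carbonyl carbon. Within the data shown here, no measured step between two compounds differing in only this way is available, so the size of this change cannot be read from the data. The step from compound 2 to compound 3 is nonetheless expected to be an at least 4.0-fold lower number from compound 2 to compound 3 (0.60 log units; beyond the scatter) in the direction of stronger inhibition, beyond the usual scatter. Compound 3 is estimated to give 8000 nM in this assay, with a range from 1500 nM to 40000 nM.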

Compound 3, half-maximal inhibitory concentration: 1200 nM
For compound 3 the middle estimate is 6.7-fold (0.82 log units) above the measured one, and the stated range ends above it.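

With the propyl chain held fixed, the group on the carbonyl carbon alone decides whether inhibition can be read in this assay (an at least 26-fold lower number from compound 2 to compound 3 (1.42 log units; beyond the scatter)). Among these compounds, this is the first comparison in which only one place changes, and it shows that this position matters: with 3,4-difluorophenyl in place of pyridin-2-yl, a compound known only by a limit becomes one with a measured value. From the compounds shown here alone, the printed step is a lower bound and its true size remains unknown, because it rests on a limit of the assay for compound 2: (the limit of > 32000 nM in this assay, at which 1 of the 3 values shown sits).

A plain phenyl group on the carbonyl carbon, with the propyl chain kept, would show whether the gain follows the two fluorine atoms or the loss of the ring nitrogen. Compound 1 differs from compound 3 in both the chain on the amine and the group on the carbonyl carbon, which leaves the effect of the chain alone unread.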